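Chlorine Count on the Aryl Ether and Enzyme Inhibition

The source may report more compounds than this note shows. Statements on the series, on what has been measured and on what is new or still open speak of the compounds shown alone.

Compound 1 `NC1=NC2(CCSCC2)N(OCCCOc2ccc(Cl)cc2)C(N)=N1` gives "not determined" (no result reported) in an assay on isolated protein for inhibition of Dihydrofolate reductase (Homo sapiens), read by spectrophotometry, using NADPH, with stated times of 5 s and 6 min, tested at 50 uM; a lower number here means a weaker effect, a higher number a stronger effect of the compound at the concentration tested. Compound 2 `COc1ccc(OCCCON2C(N)=NC(N)=NC23CCSCC3)cc1` gives 86.6%. Compound 3 `NC1=NC2(CCSCC2)N(OCCCOc2cc(Cl)c(Cl)cc2Cl)C(N)=N1` gives 94.4%.

Compound 3 stands highest of the two numbers; its nearest neighbour is compound 2, and the step of a number 7.8 percentage points higher from compound 2 to compound 3 (within the scatter) lies within the scatter, so the two cannot be ordered. Compound 4 `NC1=NC2(CCSCC2)N(OCCCOc2ccccc2Cl)C(N)=N1` differs from compound 3 in one place: 2-chlorophenyl in place of 2,4,5-trichlorophenyl on an oxygen on a saturated carbon. For the measured compounds named here, the only measured step that touches this position is the one from compound 2 to compound 3, and it stayed within the scatter, so no movement beyond the scatter is expected here either. Compound 4 is estimated at 88%, from 75% to 97%, an expected step of a number 6.4 percentage points lower from compound 3 to compound 4 (within the scatter).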

Compound 4, a percentage reported as inhibition, at one concentration (the size of the read-out at that concentration, not a potency): 89.6%
Beside the measured number, compound 4's estimate is 1.6 percentage points below it; the measured number falls inside the stated range.
By their numbers in this assay, from the lowest: compounds 2, 4 and 3 (each within the scatter of the next).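

Across this assay the change to 2-chlorophenyl gives a number 4.8 percentage points lower from compound 3 to compound 4 (within the scatter) and also a number 3 percentage points higher from compound 2 to compound 4 (within the scatter) on the same oxygen on a saturated carbon. At the concentration tested, then, neither the 2,4,5-trichlorophenyl group nor the 4-methoxyphenyl group separates from 2-chlorophenyl, and the number of chlorines on the ring does not tell these compounds apart. No evidence to hand bears on this result. The compounds shown leave open whether an amine or a carboxylic acid on the ring would give a step beyond the scatter. They also leave open what a longer chain to the aryl ether would do.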